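A pentafluorophenyl exchange on compound 2

The source may report more compounds than this note shows. Statements on the series, on what has been measured and on what is new or still open speak of the compounds shown alone.

Compound 1 `COc1ccc(-c2cc(=O)c3c(OC)cc(OC)cc3n2S(=O)(=O)c2cccc([N+](=O)[O-])c2)cc1`: > 39600 nM, a limit
Compound 2 `COc1ccc(-c2cc(=O)c3c(OC)cc(OC)cc3n2S(=O)(=O)c2ccc(C)c([N+](=O)[O-])c2)cc1`: > 51700 nM, a limit

In an ADME assay on BJ cells (Homo sapiens) for antiproliferative activity, with a stated time of 72 h (on this read-out lower numbers stand for an effect already at smaller amounts and higher numbers for an effect only at larger amounts of compound), compound 2 stands at > 51700 nM, which is a limit and not a number. Compound 3 `COc1ccc(-c2cc(=O)c3c(OC)cc(OC)cc3n2S(=O)(=O)c2c(F)c(F)c(F)c(F)c2F)cc1` has 2,3,4,5,6-pentafluorophenyl in place of 4-methyl-3-nitrophenyl on a sulfonyl sulfur. Among the measured compounds shown here, the only measured step is a step that the two limits leave unreadable from compound 1 to compound 2, methyl in place of hydrogen on an aromatic carbon, and it offers no size to carry over. No step beyond the scatter is therefore expected in this assay. The expected change is an at least 1.2-fold lower number from compound 2 to compound 3 (0.11 log units; that floor lies within the scatter), and it is only loosely estimated. For compound 3 the estimate is 40000 nM, with an expected range from 10000 nM to 90000 nM.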

Compound 3, half-maximal effective concentration: > 34400 nM
Compound 3: no number, only a limit; the forecaster's own chance of this, stated with the estimate: 65%; the middle value is on the limit's open side.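

Compound 1, compound 2 and compound 3 each give only a limit in this assay, and the steps among them cannot be read. The compounds shown leave open whether either sulfonyl substituent exchange changes the read-out at all.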